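Shortening the ether chain from isobutoxy to ethoxy

This account rests on a few compounds, and the source may have more. Where it says the series, first, only, none or still open, it means among the compounds named here.

The measured compounds and their values in a functional assay on KBVIN cells (Homo sapiens) for antiproliferative activity, read by sulforhodamine B assay, with a stated time of 3 days; on this read-out lower numbers stand for an effect already at smaller amounts and higher numbers for an effect only at larger amounts of compound:
Compound 1, `CCCOC1=C(CCC)C(=O)/C(=C(O)/C=C/c2ccccc2)C(=O)C1(CCC)CCC`, gives 2.4 uM.
Compound 2, `CCCC1=C(OCC(C)C)C(CCC)(CCC)C(=O)/C(=C(O)\C=C\c2ccccc2)C1=O`, gives 4.1 uM.
Compound 3, `CCCC1=C(OC)C(CCC)(CCC)C(=O)/C(=C(O)\C=C\c2ccc(I)cc2)C1=O`, gives 1.4 uM.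

Compound 2 has the highest of these three numbers. Its nearest neighbour is compound 1, a gap that lies within the usual scatter; compound 3 lies furthest away, beyond the scatter, but compound 3 differs from compound 2 in more than one place, so its value alone cannot anchor a single change.

Compound 4, `CCCC1=C(OCC)C(CCC)(CCC)C(=O)/C(=C(O)\C=C\c2ccccc2)C1=O`, differs from compound 2 by methyl in place of isopropyl on a saturated chain carbon bound to an oxygen on an unsaturated carbon. Going by the values given here, the one measured step at this place is a 1.7-fold higher number from compound 1 to compound 2 (0.23 log units; within the scatter), which added a branch to the ether chain and moved the number only within the scatter. Compound 4 goes the other way, to a chain shorter than in either compound 1 or compound 2. Since that earlier step was so small, no change beyond the scatter is expected for compound 4 in this assay, with at most a slight drift toward the lower number of compound 1.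

Compound 4 is therefore estimated at 2.8 uM, within 1.4 uM to 5.6 uM, an expected step of a 1.5-fold lower number from compound 2 to compound 4 (0.17 log units; within the scatter).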

Compound 4, concentration for half-maximal effect: 3.5 uM
Compound 4: middle estimate off by 1.3-fold (0.10 log units), on the low side, and the stated range covers the measured number.
By their numbers in this assay, from the lowest: compounds 3, 1, 4 and 2 (each within the scatter of the next, the first and the last beyond it).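

Removing the branch and shortening the ether chain from isobutoxy to ethoxy gives only a small step in this assay (a 1.2-fold lower number from compound 2 to compound 4 (0.07 log units; within the scatter)), so this change is now measured directly and stays within the scatter. The comparison with the propoxy chain of compound 1 is also small (a 1.5-fold higher number from compound 1 to compound 4 (0.16 log units; within the scatter)), which extends the earlier picture: with the rest of the structure held constant, the ethoxy, propoxy and isobutoxy chains of compound 4, compound 1 and compound 2 cannot be told apart in this read-out, and no trend with chain size or branching can be read from them. No independent measurement is available to explain this flat result.

Still open, from the compounds shown here alone, is whether the same tolerance holds for chains well outside this small set, such as an octyloxy chain or an ethoxy chain ending in an amine or a carboxylic acid. The methoxy group also remains unresolved, since compound 3 differs from these compounds in more than one place and its value cannot be assigned to that ether alone.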